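From 2-Methylphenyl to 3-Nitrophenyl in an Antiproliferative Series

This account rests on a few compounds, and the source may have more. Where it says the series, first, only, none or still open, it means among the compounds named here.

Measured in a functional assay on K562 cells (Homo sapiens) for antiproliferative activity, read by MTT assay; a lower number here means a stronger inhibitor, a higher number a weaker inhibitor:
Compound 1 `Cc1ccccc1/C(=N/NC(=S)NCCCCCC(=O)NO)c1ccccc1` gives 3510 nM
Compound 2 `C/C(=N\NC(=S)NCCCCCC(=O)NO)c1cccc(Br)c1` gives 1260 nM

Of these two compounds, compound 1 stands at the higher number, 3510 nM, and is therefore the weaker inhibitor. Compound 2 gives 1260 nM, and the gap between the two lies beyond the usual scatter of repeated measurements. The next compound to be tested in this assay is compound 3 `O=C(CCCCCNC(=S)N/N=C(\c1ccccc1)c1cccc([N+](=O)[O-])c1)NO`. It carries 3-nitrophenyl in place of 2-methylphenyl on a carbon with a double bond to nitrogen.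

For the measured compounds named here, no pair of measured compounds differs in only one place, so the data offer no direct precedent for this exchange. Compound 2 also differs from compound 1 in more than one place, so it serves only as a rough guide to the spread of values. The expected change is therefore small, slightly towards a lower number, and not beyond the scatter. The estimated step is a 1.4-fold lower number from compound 1 to compound 3 (0.15 log units; within the scatter). For compound 3 the estimated value is 2500 nM, with an expected range from 800 nM to 7000 nM.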

Compound 3, half-maximal inhibitory concentration: 1630 nM
Compound 3: the middle estimate sits 1.5-fold (0.19 log units) above what was measured; the measured number falls inside the stated range.
By their numbers in this assay, from the lowest: compounds 2 and 3 (each within the scatter of the next); then compound 1.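

In this assay, for the compounds shown here, the exchange of 2-methylphenyl for 3-nitrophenyl on a carbon with a double bond to nitrogen gives a 2.2-fold lower number from compound 1 to compound 3 (0.33 log units; beyond the scatter) and so supplies the first comparison of compounds that differ in one place. It shows that this position responds to the change of aromatic group, and that a step beyond the usual scatter can come from this exchange alone, with the rest of the structure held constant. The step is modest, and the information at hand offers no measurement that would explain it.

This single exchange removes the methyl group and brings in the nitro group together, so the contribution of each to the step stays unresolved, as does the role of where each sits on its ring. As far as these compounds go, it also remains open how an amine or a carboxylic acid in place of the nitro group of 3-nitrophenyl would read in this assay and whether the same exchange would give a step of similar size on a different core.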